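Methoxy added again, with cytotoxicity still out of reach

The compounds below may be only part of what the source reports. "The series", "measured", "known", "first", "only" and "open" are said of these compounds alone.

compound 1 `COc1ccc(/C=C/[C@@](C)(/C=C/c2ccc(O)cc2)CCC=C(C)C)cc1`: > 52000 nM
compound 2 `CC(C)=CCC[C@@](C)(/C=C/c1ccccc1)/C=C/c1ccc(O)cc1`: > 52000 nM
compound 3 `C=C[C@@](C)(/C=C/c1ccc(Nc2ccccc2)cc1)CCC=C(C)C`: > 52000 nM

In a functional assay on HepG2 cells (Homo sapiens) for cytotoxicity, with a stated time of 72 h (on this read-out higher numbers stand for an effect only at larger amounts of compound and lower numbers for an effect already at smaller amounts), compound 1 gives no number but only a limit, > 52000 nM. Compound 2 gives likewise only a limit in this assay, > 52000 nM. Compound 3 too gives only a limit in this assay, > 52000 nM. Compound 1 arises from compound 2 by methoxy in place of hydrogen on an aromatic carbon. Because all three values sit at the limit of > 52000 nM in this assay, at which 3 of the 3 values shown sit, the step that the two limits leave unreadable from compound 2 to compound 1 cannot be sized. The unmeasured compound 4 `C=C[C@@](C)(/C=C/c1ccc(Nc2ccc(OC)cc2)cc1)CCC=C(C)C` arises from compound 3 by methoxy in place of hydrogen on an aromatic carbon, the same change at a place described in the same words. How the cores of compound 3 and compound 2 differ is not broken down here. The step expected in this assay is a step that the limit leaves unreadable from compound 3 to compound 4, resting on the unreadable step that the two limits leave unreadable from compound 2 to compound 1 and on the fact that every measured value sits at the limit of > 52000 nM in this assay, at which 3 of the 3 values shown sit. Compound 4 is therefore estimated at 70000 nM, between 25000 nM and 250000 nM, and most likely again only a limit.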

Compound 4, half-maximal effective concentration: > 52000 nM
Compound 4: no number, only a limit; the forecaster's own chance of this, stated with the estimate: 80%; the middle value lies beyond the limit too.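

In this assay compound 4 gives only a limit, > 52000 nM. Within the data shown here, no step can be sized from compound 3 to compound 4, or from compound 2 to compound 1, because neither pair has a number to compare: the limit of > 52000 nM in this assay, at which 4 of the 4 values shown sit. The compounds shown leave open whether methoxy in place of hydrogen changes cytotoxicity at all, and at what concentration any of them would show an effect.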